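This account rests on a few compounds, and the source may have more. Where it says the series, first, only, none or still open, it means among the compounds named here.

Measured compounds:
Compound 1, `COCn1c(=O)c(C(=O)N(C)c2ccccc2)c(O)c2cc(SC)ccc21`, gives 78% in a functional assay on the whole organism for inhibition, with Mus musculus as the target, at a dose of 32 mg/kg by the oral route; a lower number here means less inhibition, a higher number more inhibition at the dose given (going by the name of the read-out).
Compound 2, `CSc1ccc2c(c1)c(O)c(C(=O)Nc1ccccc1)c(=O)n2C`, gives 24% in this assay.
Compound 3, `CSc1ccc2c(c1)c(O)c(C(=O)N(C)C1CCCCC1)c(=O)n2C`, gives 43% in this assay.

Compound 3 stands second highest of the three numbers in this assay, above compound 2 and below compound 1. The only step shown with a single change is a number 19 percentage points higher from compound 2 to compound 3 (beyond the scatter), and it shows that a change on the amide nitrogen can move the read-out by a modest amount.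

Compound 4, `COc1ccc(N(C)C(=O)c2c(O)c3cc(SC)ccc3n(C)c2=O)cc1`, has not been measured. It differs from compound 3 in one place: 4-methoxyphenyl in place of cyclohexyl on an amide-type nitrogen. Among the measured compounds shown here, no measured step covers this exact exchange. Compound 1 also carries a phenyl ring with a methyl on the amide nitrogen and gives the highest number, but it differs from compound 4 in a second place as well, so its value is only a loose pointer. Given the value of compound 1 at 78% and that of compound 3 at 43%, compound 4 is expected to land between them, with a step of a number 17 percentage points higher from compound 3 to compound 4 (beyond the scatter) upward expected, and an estimate of 60%, within 35% to 85%.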

Compound 4, a percentage reported as inhibition, in the whole organism at one dose (the size of the read-out at that dose, not a potency): 100%
Beside the measured number, compound 4's estimate is 40 percentage points below it; the measured number lies above the stated range.
By their numbers in this assay, from the lowest: compound 2; then compound 3; then compound 1; then compound 4.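

Exchanging cyclohexyl for 4-methoxyphenyl on the amide-type nitrogen gives a number 57 percentage points higher from compound 3 to compound 4 (beyond the scatter) in this assay. This is a much bigger move than the earlier step at this amide, a number 19 percentage points higher from compound 2 to compound 3 (beyond the scatter), and it comes from changing the ring alone while the methyl on the same nitrogen stays in place, so the ring on this nitrogen can have a large effect on the read-out. Nothing available explains why the exchange has such a large effect.

The compounds shown do not separate the contribution of the aromatic ring from that of its methoxy group, which a plain phenyl on the same core could help to settle. On these data alone, how a 4-chlorophenyl, a 4-hydroxyphenyl or a pyridine ring would read on this nitrogen also remains open.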